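Hydroxymethyl added to the propyl chain of compound 2

The source may hold more compounds than are shown below. What is called first, only, known or untested is meant among the compounds shown, and "the series" means these compounds.

Compound 1 `OCCCNc1ncnc2[nH]cc(-c3cccc(Cl)c3)c12` gives 173 nM in an assay for inhibition of serine/threonine-protein kinase 3 (Homo sapiens), read by luminescence and ADP-Glo, in the presence of a further agent that is not named here; a lower number here means a stronger inhibitor, a higher number a weaker inhibitor; compound 2 `CCCN(C)c1ncnc2[nH]cc(-c3cccc(Cl)c3)c12` gives 218 nM and compound 3 `CC1(O)CCN(c2ncnc3[nH]cc(-c4cccc(Cl)c4)c23)CC1` gives 189 nM. Compound 2 holds the highest of the three numbers, but its steps to both neighbours lie within the scatter: a 1.3-fold higher number from compound 1 to compound 2 (0.10 log units; within the scatter) and a 1.2-fold lower number from compound 2 to compound 3 (0.06 log units; within the scatter), as does a 1.1-fold higher number from compound 1 to compound 3 (0.04 log units; within the scatter). Compound 4 `CC(CO)CN(C)c1ncnc2[nH]cc(-c3cccc(Cl)c3)c12` differs from compound 2 by hydroxymethyl in place of hydrogen on a saturated chain carbon bound to two saturated chain carbons. Among the compounds with values here, the steps that bear on it are those that add or remove a hydroxyl on the group attached to the core, from compound 1 to compound 2 and from compound 2 to compound 3, and both stayed within the scatter. No step beyond the scatter is therefore expected in this assay. Compound 4 is estimated at 200 nM (range 100 nM to 420 nM), a step of a 1.1-fold lower number from compound 2 to compound 4 (0.04 log units; within the scatter) expected from compound 2.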

Compound 4, half-maximal inhibitory concentration: 58 nM
Compound 4: the middle estimate sits 3.4-fold (0.54 log units) above what was measured; measured number outside the range, below it.
By their numbers in this assay, from the lowest: compound 4; then compounds 1, 3 and 2 (each within the scatter of the next).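

In this assay, within the data shown here, hydroxymethyl on the saturated chain carbon gives the first step beyond the scatter, a 3.8-fold lower number from compound 2 to compound 4 (0.58 log units; beyond the scatter). Compound 4 also separates from the other two hydroxyl-bearing compounds, a 3.3-fold lower number from compound 3 to compound 4 (0.51 log units; beyond the scatter) and a 3.0-fold lower number from compound 1 to compound 4 (0.47 log units; beyond the scatter), so carrying a hydroxyl is not enough for the lower number, and 2-(hydroxymethyl)propyl stands apart from both groups. No measurement shown explains this result.

From the compounds shown here alone, whether the lower number needs the hydroxyl or only the branch stays open. Methyl, methoxymethyl or aminomethyl on that same carbon would separate the two.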